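Fluoro on the phenyl group of compound 3

This account rests on a few compounds, and the source may have more. Where it says the series, first, only, none or still open, it means among the compounds named here.

Measured so far in an ADME assay on microsomes from liver (Rattus norvegicus, strain Sprague-Dawley) for metabolic stability, read by LC-MS, using NADPH, with a stated time of 45 min, tested at 3 uM; on this read-out lower numbers stand for a shorter-lived compound and higher numbers for a longer-lived compound:
compound 1 `C1CCC(C(CC2CCCCN2)C2CC2)CC1` gives 0.05 h
compound 2 `C1CCC(C(CC2CCCCN2)C2CCC2)CC1` gives 0.167 h
compound 3 `c1ccc(C(CC2CCCCN2)C2CCCCC2)cc1` gives 0.0667 h

Compound 3 at 0.0667 h cannot be separated from compound 1 (a 1.3-fold higher number from compound 1 to compound 3 (0.13 log units; within the scatter)) and stands under compound 2 (a 2.5-fold lower number from compound 2 to compound 3 (0.40 log units; beyond the scatter)).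

Compound 4 `Fc1ccc(C(CC2CCCCN2)C2CCCCC2)cc1` makes one change to compound 3, fluoro in place of hydrogen on an aromatic carbon, para to a large group (fluoro in place of hydrogen on an aromatic carbon).

For the measured compounds named here, no measured step touches that aromatic carbon, and no fluoro compound has been measured. All three steps swap the group on the saturated chain carbon, so they bear on this change only indirectly, as a guide to size. The largest of them, on going to compound 2 (a 3.3-fold higher number from compound 1 to compound 2 (0.52 log units; beyond the scatter)), is still modest. A step of that size or smaller is expected in this assay, perhaps slightly upward, though the direction is not settled by the data.

The estimated step is a 1.3-fold higher number from compound 3 to compound 4 (0.13 log units; within the scatter) and no change beyond the scatter is expected. For compound 4 the estimated half-life is 0.09 h with an expected range (0.045 h to 0.2 h).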

Compound 4, half-life: 0.117 h
The estimate for compound 4 lay 1.3-fold (0.11 log units) below the measured number; low and high end bracket the measured number.
By their numbers in this assay, from the lowest: compounds 1, 3, 4 and 2 (each within the scatter of the next, the first and the last beyond it).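

In this assay, for the compounds shown here, fluoro in place of hydrogen on an aromatic carbon, para to a large group, gives the first reading at this position: a 1.8-fold higher number from compound 3 to compound 4 (0.24 log units; within the scatter), so on this evidence the change cannot be told apart from repeat measurement. The standing of the compound against its neighbours does shift, since the 4-fluorophenyl group now separates from cyclopropyl, a 2.3-fold higher number from compound 1 to compound 4 (0.37 log units; beyond the scatter), a gap that phenyl did not open, while against cyclobutyl it reads a 1.4-fold lower number from compound 2 to compound 4 (0.15 log units; within the scatter), a gap that phenyl did leave beyond the scatter. Nothing measured here explains either shift, and these readings rest on a single change at one position.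

The compounds shown do not tell whether chloro, methoxy or a nitrile on the same aromatic carbon would move the half-life beyond the scatter from compound 3, or how fluoro would read on another carbon of that ring. On these data alone, whether a second fluoro on the ring, or trifluoromethyl in place of fluoro, would build on this small step also stays open.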